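A few compounds are considered here, and "the series" means these few. Any claim that something is new, unique, unknown or untested is made for them only; others in the source may bear on it.

Compound 3 `Cc1c(C(=O)OC(C)C(C)(C)C)c[nH]c1C(=O)Oc1cccnc1` gives the highest number of the three compounds measured in an assay on CHO cells for inhibition of metabotropic glutamate receptor 1 (Rattus norvegicus) (on this read-out higher numbers stand for weaker inhibition and lower numbers for stronger inhibition), at 720 nM; in this assay compound 1 `Cc1c(C(=O)OC(C)(C)C)c[nH]c1C(=O)OC(C)(C)C` gives 100 nM, and compound 2 `CCCOC(=O)c1[nH]cc(C(=O)OC(C)C(C)(C)C)c1C` gives 4 nM. The next compound, compound 4 `Cc1c(C(=O)OC(C)C(C)(C)C)c[nH]c1C(=O)OC(C)(C)C`, carries tert-butyl in place of pyridin-3-yl on an oxygen next to a carbonyl group. Going by the values given here, the one measured step that bears on this is the exchange of an alkyl group for the same pyridinyl group at the same oxygen, a 180-fold higher number from compound 2 to compound 3 (2.26 log units; beyond the scatter), a large rise. Reversing that kind of exchange is therefore expected to bring a large fall, a 24-fold lower number from compound 3 to compound 4 (1.38 log units; beyond the scatter), though the alkyl group is a different one and no step between compound 1 and compound 4 is on record. Compound 4 is thus expected to give about 30 nM in this assay, within a range of 8 nM to 150 nM.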

Compound 4, half-maximal inhibitory concentration: 17 nM
Beside the measured number, compound 4's estimate is 1.8-fold (0.25 log units) above it, within the range that was stated.
By their numbers in this assay, from the lowest: compound 2; then compound 4; then compound 1; then compound 3.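

In this assay, at this oxygen next to a carbonyl group, the change from an aromatic ring to a branched alkyl group accounts for a large part of the spread: tert-butyl in place of pyridin-3-yl gives a large fall (a 42-fold lower number from compound 3 to compound 4 (1.63 log units; beyond the scatter)). Alkyl groups also differ from one another here, though by less, with propyl giving the lower number (a 4.3-fold higher number from compound 2 to compound 4 (0.63 log units; beyond the scatter)). On the other such oxygen, 1,2,2-trimethylpropyl in place of tert-butyl also lowers the number modestly (a 5.9-fold lower number from compound 1 to compound 4 (0.77 log units; beyond the scatter)).

On these data alone, how phenyl or a longer chain such as pentyl would read in this place remains open. Nothing on hand accounts for the size of these steps.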